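Trifluoromethyl to nitro on the aromatic ring

This account rests on a few compounds, and the source may have more. Where it says the series, first, only, none or still open, it means among the compounds named here.

In a functional assay on Bel-7402 cells (Homo sapiens) for antiproliferative activity, read by MTT assay, with a stated time of 72 h (on this read-out lower numbers stand for stronger inhibition and higher numbers for weaker inhibition), compound 1 `C=C1C(=O)O[C@H]2[C@H]1CC/C(COC(=O)Cn1cc(F)c(=O)n(Cc3ccc(Cl)cc3)c1=O)=C\CC[C@@]1(C)O[C@@H]21` gives 2560 nM and compound 2 `C=C1C(=O)O[C@H]2[C@H]1CC/C(COC(=O)Cn1cc(F)c(=O)n(Cc3ccc(Br)cc3)c1=O)=C\CC[C@@]1(C)O[C@@H]21` gives 2670 nM while compound 3 `C=C1C(=O)O[C@H]2[C@H]1CC/C(COC(=O)Cn1cc(F)c(=O)n(Cc3ccc(C(F)(F)F)cc3)c1=O)=C\CC[C@@]1(C)O[C@@H]21` gives 2250 nM and so stands within the scatter of both. Compound 4 `C=C1C(=O)O[C@H]2[C@H]1CC/C(COC(=O)Cn1cc(F)c(=O)n(Cc3ccc([N+](=O)[O-])cc3)c1=O)=C\CC[C@@]1(C)O[C@@H]21` carries nitro in place of trifluoromethyl on an aromatic carbon. Three measured steps at that same carbon bear on this change (a 1.0-fold higher number from compound 1 to compound 2 (0.02 log units; within the scatter); a 1.1-fold lower number from compound 1 to compound 3 (0.06 log units; within the scatter); a 1.2-fold lower number from compound 2 to compound 3 (0.07 log units; within the scatter)) and each lies within the scatter. None of these compounds carries nitro, so this evidence is indirect. A step no larger than the scatter, in neither direction, is expected in this assay (a 1.1-fold higher number from compound 3 to compound 4 (0.03 log units; within the scatter)). The estimate for compound 4 is 2400 nM (expected range 1100 nM to 5000 nM).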

Compound 4, half-maximal inhibitory concentration: 4070 nM
Estimate against measurement, compound 4: 1.7-fold (0.23 log units) below; the measured number falls inside the stated range.
By their numbers in this assay, from the lowest: compounds 3, 1, 2 and 4 (each within the scatter of the next).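

In this assay the nitro group at this aromatic carbon stays within the scatter of all three earlier groups (a 1.8-fold higher number from compound 3 to compound 4 (0.26 log units; within the scatter); a 1.5-fold higher number from compound 2 to compound 4 (0.18 log units; within the scatter); a 1.6-fold higher number from compound 1 to compound 4 (0.20 log units; within the scatter)). So the position, para to a large group, now also tolerates a group with hydrogen-bond acceptors, which trifluoromethyl lacks, with no step beyond the scatter. No independent measurement explains these numbers. Going by these compounds, whether an amine or a carboxylic acid at this carbon would leave the scatter remains open. So does the effect of removing the substituent altogether, leaving hydrogen on that carbon.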